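The source may hold more compounds than are shown below. What is called first, only, known or untested is meant among the compounds shown, and "the series" means these compounds.

In a functional assay on HCC1806 cells (Homo sapiens) for inhibition, read by sulforhodamine B assay, tested at 10 uM (a higher number here means more inhibition at the concentration tested (going by the name of the read-out), a lower number less inhibition), two compounds of this series have been measured. Compound 1, `CN(C)c1ccc(C2CC(c3ccc(-n4cncn4)cc3)=NN2S(=O)(=O)c2ccc(C(F)(F)F)cc2)cc1`, gives 37%; compound 2, `CN(C)c1ccc(C2CC(c3ccc(-n4cncn4)cc3)=NN2S(=O)(=O)c2ccc(C#N)cc2)cc1`, gives 33.1%. Among the compounds with values here, the one measured step, a number 3.9 percentage points lower from compound 1 to compound 2 (within the scatter), falls inside the scatter, so the two values cannot be told apart. Compound 2 therefore stands as the lower of two numbers, with compound 1 nearest to it and no separation between them that the assay would resolve.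

Compound 3, `CN(C)c1ccc(C2CC(c3ccc(-n4ccnc4)cc3)=NN2S(=O)(=O)c2ccc(C#N)cc2)cc1`, is the next compound to be measured. Its difference from compound 2 is 1H-imidazol-1-yl in place of 1H-1,2,4-triazol-1-yl on an aromatic carbon. Within the data shown here, the only measured step concerns a substituent on the sulfonyl-bearing aromatic ring, not the five-membered aromatic ring that is exchanged here, so no measured step bears directly on this change, and the step from compound 1 to compound 2 shows only that a change elsewhere in the molecule left the read-out within the scatter. On this basis the step expected here, a number 0.1 percentage points lower from compound 2 to compound 3 (within the scatter), is none beyond the scatter. Compound 3 is therefore estimated to give 33%, with a range from 15% to 50%.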

Compound 3, a percentage reported as inhibition, at one concentration (the size of the read-out at that concentration, not a potency): 4.7%
Compound 3: the middle estimate sits 28.3 percentage points above what was measured; the whole stated range lies above it.
By their numbers in this assay, from the lowest: compound 3; then compounds 2 and 1 (each within the scatter of the next).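

In this assay, the exchange of 1H-1,2,4-triazol-1-yl for 1H-imidazol-1-yl, on an aromatic carbon para to a large group, is the first change among these compounds to move the read-out beyond the scatter, giving a number 28.4 percentage points lower from compound 2 to compound 3 (beyond the scatter). The two groups both hold 5 heavy atoms and form one five-membered aromatic ring, differing only as 2 carbon and 3 nitrogen against 3 carbon and 2 nitrogen, so this position responds strongly to a change that leaves the size of the group as it was. The exchange of trifluoromethyl for nitrile at the other end of the molecule stayed within the scatter, whereas this one removes most of the inhibition seen at the concentration tested, and nothing measured here accounts for that loss.

Going by these compounds, it remains open whether the same exchange would give a step of similar size with trifluoromethyl in place of the nitrile. Also open, on these data alone, is how other groups at this place would read, such as 1H-pyrazol-1-yl, 1H-tetrazol-1-yl, an amine or a carboxylic acid, and whether the read-out follows the number of ring nitrogens at all.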